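A few compounds are considered here, and "the series" means these few. Any claim that something is new, unique, unknown or untested is made for them only; others in the source may bear on it.

Compounds measured so far:
- compound 1, `CC(C)(C)NC(=O)NCCS(=O)(=O)NC(=O)c1ccc(Nc2nc(NC3(c4ccc(Cl)cc4)CC3)nc(OCC(F)(F)F)n2)cc1`: 93%
- compound 2, `O=C(NS(=O)(=O)CCNC(=O)C1CC1)c1ccc(Nc2nc(NC3(c4ccc(Cl)cc4)CC3)nc(OCC(F)(F)F)n2)cc1`: "not active" (no number reported)

In an ADME assay on microsomes from liver (Rattus norvegicus) for metabolic stability, with a stated time of 10 min (a lower number here means that less of the compound is left, a higher number that more of the compound is left), compound 1 gives 93%. In this assay compound 2 gives "not active" (no number reported), an entry that carries no number. For the measured compounds named here, compound 1 therefore stands as the only compound with a reported figure in this assay, and that figure lies close to the top of the scale, with most of the compound still remaining after the stated time.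

Compound 3, `NCCS(=O)(=O)NC(=O)c1ccc(Nc2nc(NC3(c4ccc(Cl)cc4)CC3)nc(OCC(F)(F)F)n2)cc1`, shares the core of compound 1 and differs from it in a single place: hydrogen in place of (tert-butyl)carbamoyl on an amine nitrogen. Going by the values given here, no step between two measured compounds is available to show how such a change has behaved before, so any expectation rests on compound 1 alone.

Since compound 1 already gives 93%, there is little room upward, and the step from compound 1 to compound 3 is expected to be small, either within the usual scatter or a modest move downward, a number 8 percentage points lower from compound 1 to compound 3 (within the scatter). Compound 3 is estimated at 85%, within a range from 60% to 98%.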

Compound 3, percent of the compound remaining: 100%
For compound 3 the middle estimate is 15 percentage points below the measured one; measured number above the stated range.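

In this assay, replacing (tert-butyl)carbamoyl on the amine nitrogen with hydrogen gives a number 7 percentage points higher from compound 1 to compound 3 (within the scatter). This first readable step at this position shows that the whole group, with its 7 heavy atoms, can leave the chain without moving the read-out beyond the usual scatter, so 2-(((tert-butyl)carbamoyl)amino)ethyl and 2-aminoethyl cannot be told apart here and neither compound 1 nor compound 3 can be ranked above the other. Nothing measured on these compounds gives a reason for this result.

Compound 2 carries no number, so the steps that would link it to compound 1 and compound 3 cannot be read, and this position therefore rests on a single comparison, made with both values close to the top of the scale. As far as these compounds go, it remains open whether the same reading would hold with an acetyl group or a dimethylamino group at the end of the chain, with a carboxylic acid in place of the amine, or with a longer chain carrying the amine further out.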